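A few compounds are considered here, and "the series" means these few. Any claim that something is new, unique, unknown or untested is made for them only; others in the source may bear on it.

Within the data shown here, in a functional assay on A2780 cells (Homo sapiens) for cytotoxicity, read by sulforhodamine B assay, with a stated time of 72 h (on this read-out higher numbers stand for weaker inhibition and lower numbers for stronger inhibition), compound 3 `O=C(NCc1ccc(S(=O)(=O)N2CCC(O)CC2)cc1)N1Cc2ccncc2C1` gives 98 nM, the highest number among the three compounds measured so far. Compound 1 `CCCn1cc(S(=O)(=O)c2ccc(CNC(=O)N3Cc4ccncc4C3)cc2)cn1` gives 7.3 nM and compound 2 `O=C(NCc1ccc(S(=O)(=O)C2CCN(C3COC3)CC2)cc1)N1Cc2ccncc2C1` gives 7.4 nM, and a 1.0-fold higher number from compound 1 to compound 2 (0.01 log units; within the scatter) lies within the scatter. Compound 4 `O=C(NCc1ccc(S(=O)(=O)N2CCC(N3CCCC3)CC2)cc1)N1Cc2ccncc2C1` differs from compound 3 in a single place, with pyrrolidin-1-yl in place of hydroxy on a saturated ring carbon. Among the measured compounds shown here, the only measured steps that bear on this change are those on the sulfonyl sulfur, namely a 13-fold higher number from compound 2 to compound 3 (1.12 log units; beyond the scatter) and a 13-fold higher number from compound 1 to compound 3 (1.13 log units; beyond the scatter). Both are large and beyond the scatter, and both end at the 4-hydroxypiperidin-1-yl group, but neither tests pyrrolidin-1-yl directly. On the strength of those two steps, a moderate move to a lower number is expected in this assay, closing part of the gap rather than all of it. The expected change is a 3.9-fold lower number from compound 3 to compound 4 (0.59 log units; beyond the scatter). The estimate for compound 4 is 25 nM, with an expected range from 7 nM to 90 nM.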

Compound 4, half-maximal inhibitory concentration: 5.6 nM
For compound 4 the middle estimate is 4.5-fold (0.65 log units) above the measured one; the whole stated range lies above it.
By their numbers in this assay, from the lowest: compounds 4, 1 and 2 (each within the scatter of the next); then compound 3.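

In this assay, among these compounds, the earlier steps replaced the whole group on the sulfonyl sulfur, whereas this pair isolates a single substituent on a saturated ring carbon, and pyrrolidin-1-yl in place of hydroxy gives an 18-fold lower number from compound 3 to compound 4 (1.24 log units; beyond the scatter). The 4-substituted piperidin-1-yl group on the sulfonyl sulfur therefore does not by itself set compound 3 apart, since the other two steps, a 1.3-fold lower number from compound 2 to compound 4 (0.12 log units; within the scatter) and a 1.3-fold lower number from compound 1 to compound 4 (0.12 log units; within the scatter), both lie within the scatter. Nothing in the data shown accounts for the large step at this position.

The compounds shown leave open whether the ring or the nitrogen of pyrrolidin-1-yl matters at this carbon. A dimethylamino group, a methoxy group or a cyclopentyl ring in the same place would separate the two.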